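The source may report more compounds than this note shows. Statements on the series, on what has been measured and on what is new or still open speak of the compounds shown alone.

In a functional assay on OVCAR-5 cells (Homo sapiens) for cytotoxicity, read by sulforhodamine B assay, with a stated time of 48 h, tested at 0.01 uM (on this read-out lower numbers stand for a stronger effect and higher numbers for a weaker effect at the one concentration tested), three compounds have been examined so far. Compound 1 `COc1ccc(-c2cc(/C=C/C(=O)c3ccc(OC)c(OC)c3)[nH]n2)cc1` gives 93%. Compound 2 `COc1cc(-c2cc(/C=C/C(=O)c3ccc(Cl)c(Cl)c3)[nH]n2)cc(OC)c1OC` gives 97%, and compound 3 `COc1ccc(-c2cc(/C=C/C(=O)c3ccc(N)cc3)[nH]n2)cc1` gives 99%. Compound 2 thus stands second highest of the three numbers, but its gap to compound 3, the nearest, and its gap to compound 1, the furthest, both lie within the usual scatter, so the three compounds cannot be ranked against one another on these readings.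

Compound 4 `COc1ccc(C(=O)/C=C/c2cc(-c3cc(OC)c(OC)c(OC)c3)n[nH]2)cc1OC` has not yet been measured in this assay. It differs from compound 2 in one place: 3,4-dimethoxyphenyl in place of 3,4-dichlorophenyl on a carbonyl carbon. Among the measured compounds shown here, no step between two measured compounds that differ in a single place is available to calibrate this change. What the three measured compounds show is that several different groups on the ring attached to the carbonyl carbon all give numbers within scatter of one another, because compound 1 gives 93% and compound 3 gives 99% beside compound 2. Compound 4 is therefore expected to read about 95%, with a range from 85% to 103%. The step this estimate implies, a number 2 percentage points lower from compound 2 to compound 4 (within the scatter), is expected to stay within the scatter rather than to run in either direction beyond it.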

Compound 4, a percentage reported as activity, at one concentration (the size of the read-out at that concentration, not a potency): 101%
Estimate against measurement, compound 4: 6 percentage points below, within the range that was stated.
By their numbers in this assay, from the lowest: compounds 1, 2, 3 and 4 (each within the scatter of the next).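

In this assay, among the compounds shown here, the exchange of 3,4-dichlorophenyl for 3,4-dimethoxyphenyl on a carbonyl carbon gives the first reading of a single change, a number 4 percentage points higher from compound 2 to compound 4 (within the scatter). The entering group has 10 heavy atoms and 2 hydrogen-bond acceptors and the leaving group 8 heavy atoms and 0 hydrogen-bond acceptors, yet at the one concentration tested this read-out does not separate compound 2 from compound 4. No measurement shown here gives a reason for this outcome.

The compounds shown leave open whether a carboxylic acid, a nitrile or a morpholine on the ring attached to the carbonyl carbon would give a step beyond the scatter from compound 2. They also leave open whether 3,4-dichlorophenyl and 3,4-dimethoxyphenyl would still read alike at a higher concentration, where a difference between compound 2 and compound 4 could appear that this single concentration cannot show.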